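Swapping bromo for methoxy in a growth inhibition series

The source may report more compounds than this note shows. Statements on the series, on what has been measured and on what is new or still open speak of the compounds shown alone.

Measured compounds:
- compound 1 `Nc1ccccc1NC(=O)CCCNCC(=O)Nc1ccc(Br)cc1` gives 80000 nM
- compound 2 `Nc1ccccc1NC(=O)c1ccc(NCC(=O)Nc2ccc([N+](=O)[O-])cc2)cc1` gives 42500 nM

For the measured compounds named here, both values come from a functional assay on U-251 cells (Homo sapiens) for inhibition, read by MTT assay, with a stated time of 2 days (a lower number here means a stronger inhibitor of growth, a higher number a weaker inhibitor of growth), and lie within the scatter of each other, so compound 1 stands level with compound 2 on the numbers so far. The next compound to be read is compound 3 `COc1ccc(NC(=O)CNCCCC(=O)Nc2ccccc2N)cc1`, which keeps the core of compound 1 and carries methoxy in place of bromo on an aromatic carbon. The group sits para to a large group, and the change reads 4-bromophenyl to 4-methoxyphenyl.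

Going by the values given here, no pair of measured compounds differs in one place only, so the data offer no direct measure of this change. With so little to go on, a step beyond the scatter is not expected in this assay, and no direction is clearly favoured. The expected size is a 1.2-fold lower number from compound 1 to compound 3 (0.09 log units; within the scatter), which stays small. For compound 3 the estimate is 65000 nM, with an expected range from 30000 nM to 100000 nM.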

Compound 3, concentration for total growth inhibition: > 100000 nM
Compound 3: no number, only a limit (the forecaster's own chance of this, stated with the estimate: 20%); middle value at least 1.5-fold (0.18 log units) from the limit.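

In this assay, compound 3 reads > 100000 nM, and this value is a limit of the assay, not a number. For the compounds shown here, it gives the first direct look at methoxy in place of bromo on an aromatic carbon, para to a large group, and the step is an at least 1.2-fold higher number from compound 1 to compound 3 (0.09 log units; that floor lies within the scatter), so the change has a known direction only as a floor that does not pass beyond the scatter. The true size of the step cannot be read, and the data show no more than this minimum because the value of compound 3 is capped: the limit of > 100000 nM in this assay, at which 1 of the 3 values shown sits.

The compounds shown leave open how far the 4-methoxyphenyl group really lies from the 4-bromophenyl group on this core, and whether another group at the same place, such as an amine, a hydroxyl or a chlorine, would give a value that can be read as a number in this assay. They also leave open whether methoxy would behave the same way on the core of compound 2, or on a core with a longer chain.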